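Notes on the aryl ring at the exocyclic double bond

The source may report more compounds than this note shows. Statements on the series, on what has been measured and on what is new or still open speak of the compounds shown alone.

Compound 3 `C=CCn1c(=O)/c(=C\c2ccc(C)cc2)[nH]c(=O)/c1=C\c1ccccc1OC` is reported as "not active" (no number reported) in a functional assay on Huh-7 cells (Homo sapiens) for cytotoxicity, read by CCK-8 assay, with a stated time of 72 h (on this read-out lower numbers stand for stronger inhibition and higher numbers for weaker inhibition), so it stands below the measured members without a number. Compound 1 `C=CCn1c(=O)/c(=C\c2cccc(Cl)c2Cl)[nH]c(=O)/c1=C\c1ccccc1OC` gives 1200 nM and compound 2 `C=CCn1c(=O)/c(=C\c2ccccc2C(F)(F)F)[nH]c(=O)/c1=C\c1ccccc1OC` gives 9500 nM. Compound 4 `C=CCn1c(=O)/c(=C\c2ccccc2F)[nH]c(=O)/c1=C\c1ccccc1OC` differs from compound 3 by 2-fluorophenyl in place of 4-methylphenyl on a double-bonded chain carbon bound to an aromatic carbon. For the measured compounds named here, the only step that bears on this part of the series is a 7.9-fold higher number from compound 1 to compound 2 (0.90 log units; beyond the scatter), a change of one substituted aryl ring for another at the same place; it is modest and gives no direct guide from an unmeasured starting point. The expectation is therefore a number for compound 4 near the weaker measured members, in this assay estimated at 12000 nM with a range from 2500 nM to 60000 nM.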

Compound 4, half-maximal inhibitory concentration: 31300 nM
Compound 4: middle estimate off by 2.6-fold (0.42 log units), on the low side, and the stated range covers the measured number.
By their numbers in this assay, from the lowest: compound 1; then compound 2; then compound 4.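

Fluoro in place of trifluoromethyl gives a 3.3-fold higher number from compound 2 to compound 4 (0.52 log units; beyond the scatter) and 2-fluorophenyl in place of 2,3-dichlorophenyl gives a 26-fold higher number from compound 1 to compound 4 (1.42 log units; beyond the scatter) in this assay with the rest of the molecule unchanged. Among the rings with a number, 2,3-dichlorophenyl therefore stands lowest and 2-fluorophenyl highest, while compound 3 has no number, so no step to or from it can be read. Nothing measured here accounts for these differences.

Open, going by these compounds, is how an aryl ring carrying an amine or a carboxylic acid would read at this place. Also open, on these data alone, is whether a methoxy group on the ring would give a number.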